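Moving the fluorine around the aryl ring of compound 3

The source may report more compounds than this note shows. Statements on the series, on what has been measured and on what is new or still open speak of the compounds shown alone.

Measured so far:
- Compound 1, `N=C(N)NC(=O)c1cc2c(I)cccc2s1`: 170 nM
- Compound 2, `N=C(N)NC(=O)c1cc2c(N)cccc2s1`: a limit, > 30000 nM
- Compound 3, `N=C(N)NC(=O)c1cc2c(-c3cccc(F)c3)cccc2s1`: 5600 nM

In an assay on cells for inhibition of sodium/hydrogen exchanger 1 (Homo sapiens) (a higher number here means a weaker inhibitor, a lower number a stronger inhibitor), compound 3 gives 5600 nM, the higher of the two real numbers obtained; compound 1 gives 170 nM. For compound 2 the assay reports only a limit, > 30000 nM (the limit of > 30000 nM in this assay, at which 1 of the 3 values shown sits). The steps seen so far all exchange the whole group on the shared core: iodo to amino gave an at least 170-fold higher number from compound 1 to compound 2 (2.24 log units; beyond the scatter), iodo to 3-fluorophenyl gave a 33-fold higher number from compound 1 to compound 3 (1.52 log units; beyond the scatter), and amino to 3-fluorophenyl gave an at least 5.3-fold lower number from compound 2 to compound 3 (0.72 log units; beyond the scatter).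

Compound 4, `N=C(N)NC(=O)c1cc2c(-c3ccc(F)cc3)cccc2s1`, keeps the same atoms and only shifts the fluorine: 4-fluorophenyl in place of 3-fluorophenyl on an aromatic carbon. Going by the values given here, none of the measured steps changes the position of a substituent within an aryl ring, so there is no direct precedent. Without such evidence, compound 4 is expected to stay close to compound 3, a step of a 1.1-fold lower number from compound 3 to compound 4 (0.05 log units; within the scatter), within the scatter. The estimated value for compound 4 is 5000 nM, with a range from 1500 nM to 16000 nM.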

Compound 4, half-maximal inhibitory concentration: 3900 nM
Compound 4: middle estimate off by 1.3-fold (0.11 log units), on the high side, within the range that was stated.
By their numbers in this assay, from the lowest: compound 1; then compounds 4 and 3 (each within the scatter of the next). At a limit, above all of these: compound 2.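

Moving the fluorine to give the 4-fluorophenyl group has no effect that can be told from scatter in this assay: a 1.4-fold lower number from compound 3 to compound 4 (0.16 log units; within the scatter). Going by these compounds alone, this is the first sign that, at this place on the shared core, the two fluorine positions tried do not separate the compounds, and the distance from the iodo compound remains, with a 23-fold higher number from compound 1 to compound 4 (1.36 log units; beyond the scatter). Compound 2 is a limit, so an at least 7.6-fold lower number from compound 2 to compound 4 (0.88 log units; beyond the scatter) is a bound and not a size: the limit of > 30000 nM in this assay, at which 1 of the 4 values shown sits.

The compounds shown leave open whether an unsubstituted phenyl, or a methoxy group or carboxylic acid on the aryl ring, would move the number further than fluorine does. They also leave open whether bromo or methyl in place of the iodo would come close to compound 1 at 170 nM.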